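Chloro on the phenyl ring: one place measured, another not

The source may report more compounds than this note shows. Statements on the series, on what has been measured and on what is new or still open speak of the compounds shown alone.

Measured so far:
Compound 1, `CCCCCCCCc1ccc(OCC(=O)Cn2nnnc2-c2ccccc2)cc1` — 71 nM
Compound 2, `CCCCCCCCc1ccc(OCC(=O)Cn2nnnc2-c2ccccc2Cl)cc1` — 4600 nM
Compound 3, `CCCCCCCCc1ccc(OC(C)C(=O)Cn2nnc(-c3ccccc3)n2)cc1` — 24 nM

In an assay on microsomes from brain for inhibition of Fatty-acid amide hydrolase 1 (Rattus norvegicus), read by fluorescence and HPLC, with a stated time of 60 min (a lower number here means a stronger inhibitor, a higher number a weaker inhibitor), compound 1 gives 71 nM and compound 3 gives 24 nM. The two share the long chain and the ether, but the difference between their cores is not broken down here. Compound 2 carries the change (chloro in place of hydrogen on an aromatic carbon), and in this assay compound 2 gives 4600 nM; the step of a 65-fold higher number from compound 1 to compound 2 (1.81 log units; beyond the scatter) is large, beyond the usual scatter.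

Compound 4, `CCCCCCCCc1ccc(OC(C)C(=O)Cn2nnc(-c3ccc(Cl)cc3)n2)cc1`, has not yet been measured. It arises from compound 3 by the change (chloro in place of hydrogen on an aromatic carbon). For the measured compounds named here, this is the same kind of change as the one from compound 1 to compound 2, not the same: in compound 2 the chloro sits ortho to a large group, in compound 4 it sits para to a large group, and the surrounding core is also different.

Going by the values given here, only one measured step shows what a chloro on this phenyl does, and it is at a different place. Because the step of a 65-fold higher number from compound 1 to compound 2 (1.81 log units; beyond the scatter) is large, some loss is expected for compound 4 too, but a smaller one, since the place differs. For compound 4 in this assay a value of 70 nM is expected, somewhere between 15 nM and 400 nM, which means an expected step of a 2.9-fold higher number from compound 3 to compound 4 (0.46 log units; beyond the scatter).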

Compound 4, half-maximal inhibitory concentration: 35 nM
Compound 4: the middle estimate sits 2.0-fold (0.30 log units) above what was measured; the measured number falls inside the stated range.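

In this assay the chloro on the core of compound 3, phenyl to 4-chlorophenyl, gives a 1.5-fold higher number from compound 3 to compound 4 (0.16 log units; within the scatter) and so makes no measurable difference there. The same change therefore does not carry the same size of step from one core to the other: the same change on two cores in this assay, a 65-fold higher number (1.81 log units; beyond the scatter) from compound 1 to compound 2 and a 1.5-fold higher number (0.16 log units; within the scatter) from compound 3 to compound 4, 44-fold (1.65 log units) apart, beyond the scatter of two such steps. For the compounds shown here, what this does not show is why the two steps part, since two things differ at once: the chloro in compound 4 sits para to a large group while the one in compound 2 sits elsewhere on the ring, and the cores are different as well, with only a single pair behind each step.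

The compounds shown leave open what a 4-chlorophenyl would do on the core of compound 1, and what a chloro placed as in compound 2 would do on the core of compound 3, the two pairs that could separate the place of the chloro from the core. They also leave open how other groups at the same spot on the phenyl ring, such as an amine or a carboxylic acid, would compare with chloro.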